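From nitrile to methyl ester on the shared core

This account rests on a few compounds, and the source may have more. Where it says the series, first, only, none or still open, it means among the compounds named here.

In a physicochemical assay for lipophilicity (a lower number here means a more polar compound, a higher number a more lipophilic compound), compound 1 `Fc1ccc(CC2CCC3(CC2)OOCCCOO3)cc1` gives 4.01, compound 2 `FC(F)(F)c1ccc(CC2CCC3(CC2)OOCCCOO3)cc1` gives 4.79 and compound 3 `N#Cc1ccc(CC2CCC3(CC2)OOCCCOO3)cc1` gives 3.46, the lowest of the three. Compound 4 `COC(=O)c1ccc(CC2CCC3(CC2)OOCCCOO3)cc1`, not yet measured, carries methoxycarbonyl in place of cyano on an aromatic carbon. For the measured compounds named here, two measured steps bear on this change, both bringing in cyano and both beyond the scatter: a number 0.55 log units lower from compound 1 to compound 3 (beyond the scatter) is modest and a number 1.33 log units lower from compound 2 to compound 3 (beyond the scatter) is large. Going by the values given here, no measured step removes cyano or brings in methoxycarbonyl, so the size remains uncertain. A modest rise is expected, estimated at a number 0.49 log units higher from compound 3 to compound 4 (beyond the scatter). For compound 4 the estimate is 3.95, with an expected range of 3.6 to 4.3.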

Compound 4, partition coefficient: 3.75
Compound 4: the middle estimate sits 0.20 log units above what was measured, and the stated range covers the measured number.
By their numbers in this assay, from the lowest: compounds 3, 4 and 1 (each within the scatter of the next, the first and the last beyond it); then compound 2.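

In this assay, methoxycarbonyl on this aromatic carbon, para to a large group, gives a number 0.29 log units higher from compound 3 to compound 4 (within the scatter) and a number 0.26 log units lower from compound 1 to compound 4 (within the scatter), so compound 4 cannot be separated from compound 3 or compound 1, although those two stand apart. Replacing trifluoromethyl gives a number 1.04 log units lower from compound 2 to compound 4 (beyond the scatter), leaving compound 2 clear of the other three. No supporting data on the origin of these steps are available. Open, going by these compounds, is where a carboxylic acid or an amine at this position would fall. Also open, on these data alone, is whether a longer ester chain would stay with compound 4.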